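A few compounds are considered here, and "the series" means these few. Any claim that something is new, unique, unknown or untested is made for them only; others in the source may bear on it.

Going by the values given here, compound 1 `COc1cc(NC(=O)Nc2cccc(F)c2)cc(OC)c1OC` is the only compound of the three whose result in a functional assay on Daoy cells (Homo sapiens) for cytotoxicity, read by MTT assay, with a stated time of 72 h (a lower number here means a stronger inhibitor, a higher number a weaker inhibitor), is given as a number: compound 1 gives 111000 nM. Compound 2 `COc1cc(NC(=O)Nc2cccc3cc[nH]c23)cc(OC)c1OC` reaches only the limit of this assay, reported as >= 125000 nM. Compound 3 `COc1ccc(C(=O)N(C)c2cc(OC)c(OC)c(OC)c2)cc1` likewise stops at a limit in this assay, given as >= 125000 nM. So compound 1 stands at the lower edge of what was seen, with the limit of >= 125000 nM in this assay, at which 2 of the 3 values shown sit, marking where the other two sit. Compound 4 `COc1cc(NC(=O)Nc2ccc(F)cc2)cc(OC)c1OC` differs from compound 1 by 4-fluorophenyl in place of 3-fluorophenyl on an amide-type nitrogen. Among the compounds with values here, with no comparable step measured, the change is expected to move this assay by no more than the usual scatter, in no fixed direction: the step from compound 1 to compound 4 is estimated as a 1.0-fold higher number from compound 1 to compound 4 (0.02 log units; within the scatter), and compound 4 is expected to give 115000 nM, between 55000 nM and 240000 nM.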

Compound 4, half-maximal inhibitory concentration: 104000 nM
The estimate for compound 4 lay 1.1-fold (0.04 log units) above the measured number; the range from low to high includes it.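

In this assay, 4-fluorophenyl in place of 3-fluorophenyl on an amide-type nitrogen gives a 1.1-fold lower number from compound 1 to compound 4 (0.03 log units; within the scatter). Going by these compounds alone, this is the first step that can be read at this position, and it shows that this change of the fluorophenyl group does not separate the two compounds. Two of the values shown remain limits rather than numbers: the limit of >= 125000 nM in this assay, at which 2 of the 4 values shown sit.

On these data alone, it remains open whether an amine or a carboxylic acid in place of the fluorine would move the number beyond the scatter.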